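This account rests on a few compounds, and the source may have more. Where it says the series, first, only, none or still open, it means among the compounds named here.

Measured compounds:
Compound 1, `Cc1nn([C@H](C)c2ccc(Cl)cc2Cl)c2nc(N3CC[C@@H](N4CCCCC4)[C@@H](C)C3)cnc12`, in a functional assay on cells for antagonist activity at C-C chemokine receptor type 4 (Homo sapiens), read by fluorescence and calcium flux, with stated times of 2.5 s and 45 s; on this read-out higher numbers stand for weaker inhibition and lower numbers for stronger inhibition: 803 nM
Compound 2, `C[C@@H]1CC(c2cnc3c(C#N)nn([C@H](C)c4ccc(Cl)cc4Cl)c3n2)=CC[C@@H]1N1CCC[C@H]1C(C)(C)O`, in this assay: 384 nM

Of these two numbers, compound 2 has the lower one, and its gap to compound 1 lies beyond the usual scatter. Compound 3, `C[C@@H]1CC(c2cnc3c(C#N)nn([C@H](C)c4ccc(Cl)cc4Cl)c3n2)=CC[C@@H]1N1CCC[C@H]1C(N)=O`, differs from compound 2 by one change: carbamoyl in place of 1-hydroxy-1-methylethyl on a saturated ring carbon. Going by the values given here, no measured pair shows this change, so its effect is unknown. Both groups carry one donor and one acceptor, so a step no larger than the scatter is expected from compound 2 to compound 3, in no fixed direction, a 1.3-fold higher number from compound 2 to compound 3 (0.11 log units; within the scatter). Compound 3 is therefore estimated at 500 nM, within 150 nM to 1600 nM.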

Compound 3, half-maximal inhibitory concentration: 54 nM
Compound 3: the middle estimate sits 9.3-fold (0.97 log units) above what was measured, and the stated range ends above it.
By their numbers in this assay, from the lowest: compound 3; then compound 2; then compound 1.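

The saturated ring carbon next to the ring nitrogen responds strongly to which group it carries: in this assay carbamoyl in place of 1-hydroxy-1-methylethyl gives a 7.1-fold lower number from compound 2 to compound 3 (0.85 log units; beyond the scatter) and this lies beyond the usual scatter. Both groups count the same hydrogen-bond donors and acceptors, so those counts alone do not predict the outcome at this position. Nothing measured here explains the step. Still open, from the compounds shown here alone, is how a carboxylic acid, a methyl ester or an aminomethyl group would fare on this carbon. The compounds shown also leave open whether the amide hydrogens are needed.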